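A few compounds are considered here, and "the series" means these few. Any claim that something is new, unique, unknown or untested is made for them only; others in the source may bear on it.

Measured so far in an assay for inhibition of Polyunsaturated fatty acid 5-lipoxygenase (Homo sapiens), read by HPLC, with a stated time of 10 min; on this read-out higher numbers stand for weaker inhibition and lower numbers for stronger inhibition:
- compound 1 `CCCCC(Sc1ccc(OCCCOc2cccc(C)c2)cc1)C(=O)O` gives > 10000 nM
- compound 2 `Cc1cccc(OCCCOc2ccc(SCC(=O)O)cc2)c1C` gives > 10000 nM

Notes. In this assay compound 1 reaches only a limit of the assay, > 10000 nM, and no number is given for it. Compound 2 likewise sits at a limit in this assay, > 10000 nM. Within the data shown here, compound 1 therefore stands on a limit alone, and the one further value shown is also a limit: the limit of > 10000 nM in this assay, at which 2 of the 2 values shown sit. Among the measured compounds shown here, no step between the two measured compounds is given, so the pair shows only that both lie at that limit.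

Compound 3 `CCCCC(Sc1ccc(OCCCOc2ccc(C)cc2)cc1)C(=O)O` is not yet measured in this assay. It differs from compound 1 in one place: 4-methylphenyl in place of 3-methylphenyl on an oxygen on a saturated carbon. The two have the same atoms, joined differently.

For the measured compounds named here, with compound 1 at a limit and no measured step to lean on, the step that the limit leaves unreadable from compound 1 to compound 3 is expected to be none beyond the usual scatter. Compound 3 is thus expected at 20000 nM in this assay, within 5000 nM to 100000 nM, and most likely to be reported again only as a limit rather than as a number.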

Compound 3, half-maximal inhibitory concentration: > 10000 nM
Compound 3: a limit, no number; the forecaster's own chance of this, stated with the estimate: 85%; the middle value does not contradict the limit.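

In this assay compound 3 gives > 10000 nM, a limit and not a number. Compound 1 gives > 10000 nM, also a limit. Among these compounds, no step can therefore be read between compound 1 and compound 3. The compounds shown leave open whether the position of the methyl group matters at all, as every value remains at the same limit: the limit of > 10000 nM in this assay, at which 3 of the 3 values shown sit.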